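A few compounds are considered here, and "the series" means these few. Any claim that something is new, unique, unknown or untested is made for them only; others in the source may bear on it.

Measured so far:
- compound 1 `CCCOc1cccc(-c2[nH]c3cc(OC)ccc3c(=O)c2C(=O)OCC)c1` gives > 21500 nM
- compound 2 `CCCCOc1cccc(-c2[nH]c3cc(OC)ccc3c(=O)c2C(=O)OCC)c1` gives > 21500 nM

Both entries come from an ADME assay on Raji cells (Homo sapiens) for cytotoxicity, read by luminescence, with a stated time of 72 h (a higher number here means that more compound is needed for the effect, a lower number that less compound is needed), and both are limits of the assay, not numbers. Compound 2 therefore has no exact position, and the picture so far is the limit of > 21500 nM in this assay, at which 2 of the 2 values shown sit, and nothing more.

The next compound is compound 3 `CCOC(=O)c1c(-c2cccc(Br)c2)[nH]c2cc(OC)ccc2c1=O`, which keeps the shared core and changes one group: bromo in place of butoxy on an aromatic carbon is the whole difference from compound 2.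

Among the measured compounds shown here, only one measured step comes close to this change. That step, a step that the two limits leave unreadable from compound 1 to compound 2, lengthens the chain on the same oxygen, and it has no readable size to carry over. For the measured compounds named here, no measured compound carries bromo.

The expectation therefore rests on compound 2, whose entry of > 21500 nM is a limit. Another limit is the likeliest single result for compound 3. If a number does appear, it is expected to lie only modestly toward the lower side, meaning somewhat less compound needed.

The estimated change is an at least 1.1-fold lower number from compound 2 to compound 3 (0.07 log units; that floor lies within the scatter) in this assay as the expected step. For compound 3 the expected value is 18000 nM with an estimated range of 6000 nM to 30000 nM overall.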

Compound 3, half-maximal effective concentration: > 21500 nM
Compound 3 was reported as a limit (the forecaster's own chance of this, stated with the estimate: 60%); middle value at least 1.1-fold (0.07 log units) from the limit.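

In this assay compound 3 gives > 21500 nM as a limit of the assay, not a number. Among the compounds shown here, compound 1 and compound 2 also stand at limits, so no step from either of them to compound 3 can be read. Still open is how propoxy, butoxy and bromo would compare if any of these compounds gave an exact number.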